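This account rests on a few compounds, and the source may have more. Where it says the series, first, only, none or still open, it means among the compounds named here.

Among the measured compounds shown here, in an ADME assay on L6 cells (Rattus norvegicus) for cytotoxicity, read by resazurin assay, with a stated time of 72 h (on this read-out lower numbers stand for stronger inhibition and higher numbers for weaker inhibition), compound 1 `CN1CCN(CCC(=O)N2CC3C(c4ccccc4)CC(N(C)C)(CC3c3ccccc3)C2)CC1` gives 13000 nM and compound 2 `CN(C)C12CC(c3ccccc3)C(CN(C(=O)CCN3CCCCC3)C1)C(c1ccccc1)C2` gives 12400 nM, so compound 2 stands level with the only other measured compound, within the scatter. Compound 3 `CCN(CC)CCC(=O)N1CC2C(c3ccccc3)CC(N(C)C)(CC2c2ccccc2)C1` differs from compound 2 by one change, diethylamino in place of piperidin-1-yl on a saturated chain carbon, two bonds along the chain from a carbonyl carbon. For the measured compounds named here, the one measured step at this place put piperidin-1-yl in place of 4-methylpiperazin-1-yl, and it was small: a 1.0-fold lower number from compound 1 to compound 2 (0.02 log units; within the scatter). In this assay the expected step is therefore a 1.0-fold higher number from compound 2 to compound 3 (0.02 log units; within the scatter), with no change beyond the scatter in either direction. For compound 3 the estimated value is 13000 nM, with an expected range from 7000 nM to 25000 nM.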

Compound 3, half-maximal inhibitory concentration: 15400 nM
Compound 3: middle estimate off by 1.2-fold (0.07 log units), on the low side, and the stated range covers the measured number.
By their numbers in this assay, from the lowest: compounds 2, 1 and 3 (each within the scatter of the next).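

In this assay the ring of piperidin-1-yl proves dispensable for this number: the change to diethylamino gives a 1.2-fold higher number from compound 2 to compound 3 (0.09 log units; within the scatter) and the change from 4-methylpiperazin-1-yl gives a 1.2-fold higher number from compound 1 to compound 3 (0.07 log units; within the scatter) at the same saturated chain carbon. All three amines shown at this position, with or without a ring, therefore stand level. No evidence on hand bears on this result. The compounds shown leave open whether a carboxylic acid in place of the amine, or a longer chain between the carbonyl and the amine, would move the number beyond the scatter.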